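Series notes: from compound 3 to compound 4

The compounds below may be only part of what the source reports. "The series", "measured", "known", "first", "only" and "open" are said of these compounds alone.

Measured in a functional assay on MCF7 cells (Homo sapiens) for cytotoxicity, read by MTT assay, with a stated time of 72 h; a higher number here means a weaker inhibitor, a lower number a stronger inhibitor
- compound 1 `O=C1C(=Cc2ccc(F)cc2)C(=O)N(c2ccc(Cl)cc2)N1c1ccc(Cl)cc1` gives 31400 nM
- compound 2 `O=C1C(=Cc2ccc(Br)cc2)C(=O)N(c2ccc(Cl)cc2)N1c1ccc(Cl)cc1` gives 30400 nM
- compound 3 `COc1cccc(C=C2C(=O)N(c3ccc(Cl)cc3)N(c3ccc(Cl)cc3)C2=O)c1` gives 18100 nM

Compound 3 is not separated from the other two measured compounds (a 1.7-fold lower number from compound 1 to compound 3 (0.24 log units; within the scatter)) (a 1.7-fold lower number from compound 2 to compound 3 (0.23 log units; within the scatter)). Compound 1 and compound 2 are likewise level (a 1.0-fold lower number from compound 1 to compound 2 (0.01 log units; within the scatter)).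

Compound 4 `O=C1C(=C/C=C/c2ccccc2)C(=O)N(c2ccc(Cl)cc2)N1c1ccc(Cl)cc1` brings 2-phenylethenyl in place of 3-methoxyphenyl on a double-bonded chain carbon bound to a double-bonded ring carbon. The two steps into compound 3 changed the group at this same place, and both stayed within the scatter. The bromo for fluoro step adds a smaller change on the same group. For the measured compounds named here, no measured compound carries 2-phenylethenyl, so these steps give only indirect guidance. No step beyond the scatter is therefore expected in this assay, and no direction is favoured.

The estimated step is a 1.2-fold higher number from compound 3 to compound 4 (0.08 log units; within the scatter) (a small one, with a wide margin). For compound 4 the expected value is 22000 nM (estimated range 9000 nM to 50000 nM).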

Compound 4, half-maximal inhibitory concentration: 9400 nM
Compound 4: middle estimate off by 2.3-fold (0.37 log units), on the high side; low and high end bracket the measured number.
By their numbers in this assay, from the lowest: compounds 4, 3, 2 and 1 (each within the scatter of the next, the first and the last beyond it).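

In this assay, the place on a double-bonded chain carbon bound to a double-bonded ring carbon gives its first steps beyond the scatter, with 2-phenylethenyl against 4-bromophenyl (a 3.2-fold lower number from compound 2 to compound 4 (0.51 log units; beyond the scatter)) and against 4-fluorophenyl (a 3.3-fold lower number from compound 1 to compound 4 (0.52 log units; beyond the scatter)). Against 3-methoxyphenyl, 2-phenylethenyl is not separated (a 1.9-fold lower number from compound 3 to compound 4 (0.28 log units; within the scatter)), so the separation holds only against the two halogen-bearing phenyl groups. No measurement at hand accounts for these steps, so the added double bond outside aromatic rings cannot be credited with them.

The compounds shown leave open whether a saturated 2-phenylethyl group at this place would give a number level with that of compound 4. Also open, from the compounds shown here alone, is whether an amine or a carboxylic acid on the phenyl ring of 2-phenylethenyl would move the number further.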